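Shortening the hydroxycarbamoyl chain further: what compound 4 may do

The source may report more compounds than this note shows. Statements on the series, on what has been measured and on what is new or still open speak of the compounds shown alone.

Measured so far in a functional assay on MCF7 cells (Homo sapiens) for inhibition, read by MTT assay, with a stated time of 72 h (on this read-out lower numbers stand for stronger inhibition and higher numbers for weaker inhibition), are:
- Compound 1 `Nc1ncnc2c1c(-c1cnc3[nH]ccc3c1)nn2CCCCCCCCC(=O)NO` gives 24700 nM as a number
- Compound 2 `Nc1ncnc2c1c(-c1cnc3[nH]ccc3c1)nn2CCCCCC(=O)NO` gives > 150000 nM as a limit
- Compound 3 `Nc1nc2cc(-c3nn(CC(=O)NO)c4ncnc(N)c34)ccc2o1` gives > 100000 nM as a limit

Compound 2 has only a limit (the limit of > 150000 nM in this assay, at which 1 of the 3 values shown sits) and no exact number. Compound 4 `Nc1ncnc2c1c(-c1cnc3[nH]ccc3c1)nn2CCCC(=O)NO` shortens the chain again (hydroxycarbamoyl in place of 2-(hydroxycarbamoyl)ethyl on a saturated chain carbon, three bonds along the chain from an aromatic nitrogen), with hydroxycarbamoyl in place of 2-(hydroxycarbamoyl)ethyl on a saturated chain carbon, three bonds along the chain from an aromatic nitrogen. Among the measured compounds shown here, the one measured step of this kind also shortened the chain and lies beyond the scatter (an at least 6.0-fold higher number from compound 1 to compound 2 (0.78 log units; beyond the scatter)). A similar change in the same direction is therefore expected, towards a higher number, and the expected step is (a step that the limit leaves unreadable from compound 2 to compound 4) in this assay here. Compound 4 is estimated at 250000 nM with an expected range from 100000 nM to 600000 nM and a bare limit is the likely report.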

Compound 4, half-maximal inhibitory concentration: > 150000 nM
Compound 4: only a limit was reported; the forecaster's own chance of this, stated with the estimate: 80%; the middle value does not contradict the limit.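

In this assay compound 4 gives > 150000 nM, which is a limit and not a number. Shortening the chain again brings back no readable number, and the comparison with the longest chain shown gives an at least 6.0-fold higher number from compound 1 to compound 4 (0.78 log units; beyond the scatter). Compound 2 and compound 4 both stand at a limit, so the step between them cannot be read, and any further loss stays hidden: the limit of > 150000 nM in this assay, at which 2 of the 4 values shown sit.

Still open, on these data alone, is whether a longer chain than that of compound 1 gives a lower number. Also open, as far as these compounds go, is whether a carboxylic acid in place of hydroxycarbamoyl keeps the inhibition of compound 1.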